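The source may report more compounds than this note shows. Statements on the series, on what has been measured and on what is new or still open speak of the compounds shown alone.

Compound 1 `COc1cc(OC)c(/C=C/S(=O)(=O)Cc2ccc(OC)c(N)c2)c(OC)c1` gives 4 nM
Compound 2 `COc1ccc(CS(=O)(=O)/C=C/c2c(OC)cc(O)cc2OC)cc1N` gives 200 nM
Compound 3 `COc1cc(OC)c(/C=C/S(=O)(=O)Cc2ccc(Br)c(N)c2)c(OC)c1` gives 750 nM

All three numbers come from a functional assay on DU-145 cells (Homo sapiens) for cytotoxicity, read by trypan blue exclusion, with a stated time of 96 h (on this read-out lower numbers stand for stronger inhibition and higher numbers for weaker inhibition), and compound 1 holds the lowest of them, which makes it the most potent of the three. Single changes to it have cost a great deal. Hydrogen in place of methyl on an oxygen on an aromatic ring gave a 50-fold higher number from compound 1 to compound 2 (1.70 log units; beyond the scatter) and bromo in place of methoxy on an aromatic carbon gave a 190-fold higher number from compound 1 to compound 3 (2.27 log units; beyond the scatter) in turn.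

Compound 4 `COC(=O)C(Nc1cc(CS(=O)(=O)/C=C/c2c(OC)cc(OC)cc2OC)ccc1OC)c1ccc(F)cc1` has not yet been measured. It carries (4-fluorophenyl)(methoxycarbonyl)methyl in place of hydrogen on a nitrogen on an aromatic ring, and the count of that change is (4-fluorophenyl)(methoxycarbonyl)methyl in place of hydrogen on a nitrogen on an aromatic ring as computed from the two structures. Neither measured step touches this nitrogen, so the data give no direct reading of such a change. Among the measured compounds shown here, they show only that both changes tried on compound 1 raised the number, well beyond the scatter. A step upward in this assay is therefore expected, though its size is uncertain. The estimated step is a 15-fold higher number from compound 1 to compound 4 (1.18 log units; beyond the scatter) and it is expected to be smaller than the two measured ones. The expected value for compound 4 is 60 nM with an estimated range from 8 nM to 500 nM around it.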

Compound 4, half-maximal inhibitory concentration: 300 nM
Beside the measured number, compound 4's estimate is 5.0-fold (0.70 log units) below it, within the range that was stated.
By their numbers in this assay, from the lowest: compound 1; then compounds 2 and 4 (each within the scatter of the next); then compound 3.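

In this assay the nitrogen on an aromatic ring turns out to be a sensitive place too: (4-fluorophenyl)(methoxycarbonyl)methyl in place of hydrogen there gives a 75-fold higher number from compound 1 to compound 4 (1.88 log units; beyond the scatter) and so counts as a large step, well beyond the usual scatter. This is the first reading at this nitrogen, and it shows that a large group of 12 heavy atoms, carrying its own aromatic ring, is not tolerated there without a heavy cost, so the nitrogen joins the other two changed places in raising the number, and no single change shown improves on compound 1. Nothing measured here explains why this change costs so much.

The entering group has several parts, and the compounds shown leave open whether the cost comes from the 4-fluorophenyl ring, from the methoxycarbonyl group, or simply from replacing the hydrogen on the nitrogen. A single methyl or an acetyl on the nitrogen, or a carboxylic acid in place of the methyl ester, would help separate these possibilities.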